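The source may hold more compounds than are shown below. What is called first, only, known or untested is meant among the compounds shown, and "the series" means these compounds.

Measured so far:
Compound 1, `Cn1c(-c2ccccc2)cnc1NC(=O)c1ncc[nH]1`: 1.47 h
Compound 2, `O=C(Nc1ncc(-c2ccccc2)o1)c1ccc(F)cc1`: 0.317 h

In an ADME assay on microsomes from liver (Homo sapiens) for metabolic stability (on this read-out lower numbers stand for a shorter-lived compound and higher numbers for a longer-lived compound), compound 1 gives 1.47 h, the higher of the two numbers; compound 2 gives 0.317 h, a gap that lies beyond the usual scatter. Compound 3, `Cn1c(-c2cccc(Cl)c2)cnc1NC(=O)c1ncc[nH]1`, has not yet been measured. It differs from compound 1 in one place: chloro in place of hydrogen on an aromatic carbon. Among the compounds with values here, no measured pair shows this change, so there is no step to lean on. The change from compound 1 to compound 3 is expected to be small, a 1.1-fold higher number from compound 1 to compound 3 (0.04 log units; within the scatter), and within the scatter. Compound 3 is therefore estimated at 1.6 h, with a range from 0.8 h to 3.2 h.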

Compound 3, half-life: 3.82 h
Compound 3: middle estimate off by 2.4-fold (0.38 log units), on the low side; the whole stated range lies below it.
By their numbers in this assay, from the lowest: compound 2; then compound 1; then compound 3.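

In this assay the change from phenyl to 3-chlorophenyl gives a 2.6-fold higher number from compound 1 to compound 3 (0.41 log units; beyond the scatter). This single-place comparison shows that this ring position is sensitive to substitution: one added chlorine atom moves the compound toward the longer-lived end of the read-out. No available evidence explains the rise. As far as these compounds go, whether a fluoro, a methoxy or an amine at the same place would shift the half-life in the same direction remains open. So does whether chloro elsewhere on this ring, or on another core, would have a similar effect.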